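Cyclopentyl to cyclopropylmethyl on the series

A few compounds are considered here, and "the series" means these few. Any claim that something is new, unique, unknown or untested is made for them only; others in the source may bear on it.

In a functional assay on RAW264.7 cells (Mus musculus) for inhibition, read by Griess assay, with stated times of 2 h and 24 h (a higher number here means a weaker inhibitor, a lower number a stronger inhibitor), compound 1 (`COc1ccc([C@@H]2CC(=O)c3c(O)cc(OCc4cn(C5CCCC5)nn4)cc3O2)cc1O`) gives 10500 nM and lies within the scatter of both other measured compounds. These are compound 2 (`COc1ccc([C@@H]2C/C(=N\O)c3c(O)cc(OCc4cn(Cc5ccccc5C)nn4)cc3O2)cc1O`) at 18000 nM and compound 3 (`COc1ccc([C@@H]2C/C(=N\O)c3c(O)cc(OCc4cn(Cc5ccccc5F)nn4)cc3O2)cc1O`) at 5710 nM in the same test. Both differ from compound 1 in more than one place, so neither gives a direct comparison with it.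

The next comparison leads to compound 4 (`COc1ccc([C@@H]2CC(=O)c3c(O)cc(OCc4cn(CC5CC5)nn4)cc3O2)cc1O`), which differs from compound 1 as follows: cyclopropylmethyl in place of cyclopentyl on an aromatic nitrogen. In short, cyclopropylmethyl stands in place of cyclopentyl on an aromatic nitrogen, and the rest of the structure is unchanged.

Among the measured compounds shown here, only one measured step bears on this, and only indirectly. It is a 3.2-fold lower number from compound 2 to compound 3 (0.50 log units; beyond the scatter) and counts as modest. That step is fluoro in place of methyl on an aromatic carbon, within the group carried on the same aromatic nitrogen. It shows that a small edit there can move the number beyond the scatter, but it gives no direction for the present exchange. No step beyond the scatter is therefore expected in this assay, and the range is kept wide.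

The expected change is a 1.1-fold lower number from compound 1 to compound 4 (0.02 log units; within the scatter) and neither direction is favoured. For compound 4 the estimated value is 10000 nM with an expected range from 4000 nM to 25000 nM in this test.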

Compound 4, half-maximal inhibitory concentration: 11900 nM
Compound 4: the middle estimate sits 1.2-fold (0.08 log units) below what was measured, and the stated range covers the measured number.
By their numbers in this assay, from the lowest: compounds 3, 1, 4 and 2 (each within the scatter of the next, the first and the last beyond it).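

In this assay, among the compounds shown here, the exchange of cyclopentyl for cyclopropylmethyl on the aromatic nitrogen gives a 1.1-fold higher number from compound 1 to compound 4 (0.05 log units; within the scatter), so this is the first direct reading at this position with the carbonyl form of the core held constant. The earlier step, a 3.2-fold lower number from compound 2 to compound 3 (0.50 log units; beyond the scatter), showed that an edit within the group on this nitrogen can move the number beyond the scatter, whereas this exchange of one carbocyclic group for another, five heavy atoms leaving and four entering, does not. Within this single pair, the five-membered ring attached directly to the nitrogen and the three-membered ring attached through its methyl are therefore not separated by this read-out, and no measurement on hand offers an explanation for the result.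

As far as these compounds go, it remains open whether a group carrying an amine or a carboxylic acid, or a longer chain such as n-hexyl, on the same aromatic nitrogen would move the number beyond the scatter. For the compounds shown here, it is also open whether cyclopropylmethyl and cyclopentyl would stay equally close on the oxime form of the core, where the only step available concerns fluoro and methyl on an aromatic carbon.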